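Sulfonyl aryl swap in the benzylamide series

This account rests on a few compounds, and the source may have more. Where it says the series, first, only, none or still open, it means among the compounds named here.

For the measured compounds named here, compound 1 `O=C(NCc1ccc(S(=O)(=O)c2cc(F)cc(F)c2)cc1)c1cc2ccncc2o1` gives 77% in an ADME assay on microsomes from liver (Homo sapiens) for metabolic stability, read by LC-MS, with a stated time of 30 min, tested at 1 uM (on this read-out higher numbers stand for a more stable compound and lower numbers for a less stable compound), the second highest of the three numbers measured so far. Compound 2 `O=C(NCc1ccc(S(=O)(=O)c2cc(F)cc(F)c2)cc1)c1cc2cnccc2[nH]1` gives 82% in this assay, and compound 3 `O=C(NCc1ccc(S(=O)(=O)c2ccccc2)cc1)c1cc(-c2cccnc2)no1` gives 69% in this assay; both numbers lie within the scatter of compound 1. Going by the values given here, the only single-point step measured, a number 5 percentage points higher from compound 1 to compound 2 (within the scatter), concerns the group on the carbonyl carbon and leaves the sulfonyl side untouched. Compound 4 `O=C(NCc1ccc(S(=O)(=O)c2cccc(C(F)(F)F)c2)cc1)c1cc2ccncc2o1` is compound 1 changed on the sulfonyl sulfur: 3-(trifluoromethyl)phenyl in place of 3,5-difluorophenyl on a sulfonyl sulfur. Among the compounds with values here, no measured step bears on the aryl on the sulfonyl sulfur; compound 3 carries an unsubstituted phenyl there but also a different core, so its number cannot be split into parts. No step beyond the scatter is therefore expected in this assay for this change. Compound 4 is estimated at 74%, with a range from 55% to 90%. The expected step of a number 3 percentage points lower from compound 1 to compound 4 (within the scatter) is small and within the scatter.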

Compound 4, percent of the compound remaining: 48%
Compound 4: middle estimate off by 26 percentage points, on the high side; the whole stated range lies above it.
By their numbers in this assay, from the lowest: compound 4; then compounds 3, 1 and 2 (each within the scatter of the next, the first and the last beyond it).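

On the aryl on the sulfonyl sulfur, this assay does respond: 3-(trifluoromethyl)phenyl in place of 3,5-difluorophenyl gives a number 29 percentage points lower from compound 1 to compound 4 (beyond the scatter) as the result of this single change. For the compounds shown here, the earlier single-place step on the carbonyl carbon, a number 5 percentage points higher from compound 1 to compound 2 (within the scatter), gave no such separation, so of the two steps that can be read, only the one on the sulfonyl sulfur lies beyond the scatter. Nothing available bears on the reason for this drop.

The compounds shown leave open whether the drop goes with the trifluoromethyl group itself or with the loss of the two fluorine substituents, and whether it carries over to the core of compound 2. A plain phenyl on the core of compound 1, or a methoxy or nitrile on that aryl, would help to separate these readings.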